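Swapping Bromophenyl for Acetamidophenyl on a Shared Core

This account rests on a few compounds, and the source may have more. Where it says the series, first, only, none or still open, it means among the compounds named here.

Of the compounds shown here, three built on one shared core have been tested in an ADME assay on HUVEC cells (Homo sapiens) for antiproliferative activity, read by MTT assay, with a stated time of 48 h; on this read-out lower numbers stand for stronger inhibition and higher numbers for weaker inhibition. Compound 1 `Cc1ccccc1-n1nncc1CN1C(=O)C2(C(C#N)=C(N)Oc3c(N)cc4nc5ccccc5nc4c32)c2ccccc21` carries a 2-methylphenyl group on an aromatic nitrogen. In this assay compound 1 gives > 50000 nM, which is a limit of the assay. Compound 2 `Cc1cccc(-n2nncc2CN2C(=O)C3(C(C#N)=C(N)Oc4c(N)cc5nc6ccccc6nc5c43)c3ccccc32)c1` bears a 3-methylphenyl group instead, and in this assay compound 2 gives > 50000 nM, also a limit. Compound 3 `N#CC1=C(N)Oc2c(N)cc3nc4ccccc4nc3c2C12C(=O)N(Cc1cnnn1-c1cccc(Br)c1)c1ccccc12` carries a 3-bromophenyl group, and in this assay compound 3 gives > 50000 nM, once more a limit. Because (the limit of > 50000 nM in this assay, at which 3 of the 3 values shown sit), every step among these three is unreadable: a step that the two limits leave unreadable from compound 1 to compound 2, a step that the two limits leave unreadable from compound 1 to compound 3 and a step that the two limits leave unreadable from compound 2 to compound 3. Compound 4 `CC(=O)Nc1ccc(-n2nncc2CN2C(=O)C3(C(C#N)=C(N)Oc4c(N)cc5nc6ccccc6nc5c43)c3ccccc32)cc1` has not yet been measured. It differs from compound 3 in one place: 4-acetamidophenyl in place of 3-bromophenyl on an aromatic nitrogen. Among the compounds with values here, none of the measured steps gives a readable size, so no direction can be read for the expected step of a number no higher from compound 3 to compound 4 (the limit leaves the size open) in this assay. Compound 4 is therefore expected to give about 50000 nM, with a range from 20000 nM to 150000 nM, and most likely again only a limit.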

Compound 4, half-maximal inhibitory concentration: > 50000 nM
Compound 4: only a limit was reported; the forecaster's own chance of this, stated with the estimate: 85%; the middle value sits exactly at the limit.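

Compound 4 adds no readable step: its comparisons with compound 1, compound 2 and compound 3 all stay unreadable, for one reason: the limit of > 50000 nM in this assay, at which 4 of the 4 values shown sit. The compounds shown leave open how strong any of the four is in this assay, and whether changing the group on the aromatic nitrogen alters that at all.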